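A few compounds are considered here, and "the series" means these few. Any claim that something is new, unique, unknown or untested is made for them only; others in the source may bear on it.

Compound 1 `O=C(O)[C@H](CO)NC(=O)[C@H]1C[C@H](O)CN1` gives > 12 h
Compound 2 `O=C(O)[C@@H](CO)NC(=O)[C@H]1C[C@H](O)CN1` gives > 12 h
Compound 3 `O=C(O)[C@H](CO)NC(=O)[C@@H]1C[C@H](O)CN1` gives > 12 h

In an ADME assay for metabolic stability, read by HPLC, in simulated gastric fluid, with a stated time of 12 h, at pH 1.2 (a lower number here means that the compound disappears faster, a higher number that the compound lasts longer), compound 1 gives > 12 h, a limit of the assay. Compound 2 likewise gives > 12 h, a limit. Compound 3 gives > 12 h, again a limit, so compound 3 sits at the same limit as the other two (the limit of > 12 h in this assay, at which 3 of the 3 values shown sit). The steps a step that the two limits leave unreadable from compound 1 to compound 2, a step that the two limits leave unreadable from compound 1 to compound 3 and a step that the two limits leave unreadable from compound 2 to compound 3 are all between compounds that differ only in configuration the fact that compounds 1 and 2 differ only in the configuration as drawn the fact that compounds 1 and 3 differ only in the configuration as drawn (the fact that compounds 2 and 3 differ only in the configuration as drawn), and none can be read in size. Compound 4 `O=C(N[C@H](CO)C(=O)O)[C@@H]1C[C@@H](O)CN1` differs from compound 3 thus: the two compounds have the same atoms and bonds and differ only in configuration as drawn: 2 of 3 stereo elements differ; a stereocentre at a saturated chain carbon is drawn S in compound 3 and R in compound 4; a stereocentre at a saturated ring carbon is drawn S in compound 3 and R in compound 4. Every measured change of configuration left the value at the limit, so no step beyond the scatter is expected, and the step that the limit leaves unreadable from compound 3 to compound 4 is estimated accordingly. Compound 4 is therefore expected at 14 h, within 9 h to 30 h.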

Compound 4, half-life in the ADME assay: > 12 h
Compound 4: no number, only a limit; the forecaster's own chance of this, stated with the estimate: 85%; the middle value is on the limit's open side.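

In the ADME assay compound 4 sits at the same limit as compound 1, compound 2 and compound 3. In a physicochemical assay for metabolic stability, read by HPLC, with a stated time of 12 h, at pH 4.5 (on this read-out higher numbers stand for a longer-lived compound and lower numbers for a shorter-lived compound), compound 3 gives > 12 h, a limit of the assay. In the physicochemical assay compound 4 gives > 12 h, also a limit. No step among these compounds can be read. The compounds shown leave open whether any of these changes of configuration alters the half-life.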